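The source may hold more compounds than are shown below. What is called first, only, known or untested is meant among the compounds shown, and "the series" means these compounds.

Measured compounds:
compound 1 `Nc1n[nH]c2cc(-c3cn([C@@H]4CN[C@H](C(=O)Nc5ccc(Cl)c(C(F)(F)F)c5)C4)nn3)ccc12` — 48.2%
compound 2 `CC(=O)Nc1n[nH]c2cc(-c3cn([C@@H]4CN[C@H](C(=O)Nc5ccc(Cl)c(C(F)(F)F)c5)C4)nn3)ccc12` — 23.4%
compound 3 `Nc1nc2ccc(-c3cn([C@@H]4CN[C@H](C(=O)Nc5ccc(F)c(F)c5)C4)nn3)nc2s1` — 27.4%

The three measured compounds were tested in a functional assay on K562/Adr cells (Homo sapiens) for inhibition, read by MTT assay, with a stated time of 48 h, tested at 30 uM; on this read-out higher numbers stand for more inhibition at the one concentration tested (going by the name of the read-out) and lower numbers for less inhibition. Compound 1 gives 48.2% in this assay, and compound 2, which differs from it by acetyl in place of hydrogen on a nitrogen on an aromatic ring, gives 23.4%. The step of a number 24.8 percentage points lower from compound 1 to compound 2 (beyond the scatter) therefore lowers the read-out noticeably. Compound 3 gives 27.4% in this assay; its value and that of compound 2 lie within the scatter of each other, while compound 1 stands clearly higher than compound 3. The difference between the core of compound 1 and the core of compound 3 is not broken down here.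

Compound 4 `CC(=O)Nc1nc2ccc(-c3cn([C@@H]4CN[C@H](C(=O)Nc5ccc(F)c(F)c5)C4)nn3)nc2s1` has not yet been measured. It differs from compound 3 by acetyl in place of hydrogen on a nitrogen on an aromatic ring, which is the same change as that from compound 1 to compound 2, made at a place described in the same words. Because the earlier step of a number 24.8 percentage points lower from compound 1 to compound 2 (beyond the scatter) lowered the read-out by a modest amount, a step in the same direction is expected from compound 3 to compound 4, though the lower starting point of compound 3 leaves less room for a drop of the same size. The expected step is a number 19.4 percentage points lower from compound 3 to compound 4 (beyond the scatter). Compound 4 is therefore estimated to give 8% in this assay, with a likely range from -5% to 22%.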

Compound 4, a percentage reported as inhibition, at one concentration (the size of the read-out at that concentration, not a potency): 38.4%
The estimate for compound 4 lay 30.4 percentage points below the measured number; the whole stated range lies below it.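

On the second core, acetyl in place of hydrogen on a nitrogen on an aromatic ring gave a number 11 percentage points higher from compound 3 to compound 4 (beyond the scatter) in this assay. Set beside the first case, the same amino to acetamido change went the opposite way, so in these two pairs neither its direction nor its size carried from one core to the other: the same change on two cores in this assay, a number 24.8 percentage points lower (beyond the scatter) from compound 1 to compound 2 and a number 11 percentage points higher (beyond the scatter) from compound 3 to compound 4, 35.8 percentage points apart, beyond the scatter of two such steps This does not show which structural difference accounts for the reversal, since the pair of compound 1 and compound 2 and the pair of compound 3 and compound 4 differ from each other both in the core and in the halogen-bearing group at the amide end, and two pairs tested at a single concentration support no general rule for the series.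

On these data alone, it remains open whether the opposite steps follow the core or the amide end, which the same change on a core carrying the other end group could separate. As far as these compounds go, it is also open how a propionyl or a methanesulfonyl group in place of the acetyl would behave on the nitrogen of either core.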